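The compounds below may be only part of what the source reports. "The series", "measured", "known", "first", "only" and "open" are said of these compounds alone.

Measured so far in an assay for activation of interferon regulatory factor 3 (Homo sapiens), read by a luciferase reporter, with a stated time of 20 h; a lower number here means that less compound is needed, a higher number that more compound is needed for the effect:
- compound 1, `CCCn1c(NC(=O)c2ccc3ccccc3n2)nc2cc(C(N)=O)cc(OC)c21`: compound 1 gives > 100000 nM, a limit of the assay.
- compound 2, `CCCn1c(NC(=O)c2ccccn2)nc2cc(C(N)=O)cc(OC)c21`: compound 2 gives > 100000 nM, likewise a limit of the assay.

Compound 2 therefore stands in this assay only at a limit, not at a number; its position relative to compound 1 is not readable. Among the compounds with values here, the single measured step, a step that the two limits leave unreadable from compound 1 to compound 2, is unreadable because of the limit of > 100000 nM in this assay, at which 2 of the 2 values shown sit. Nothing in the measured pair shows a direction or a size for exchanging the ring on the carbonyl carbon.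

Compound 3, `CCCn1c(NC(=O)c2cccnn2)nc2cc(C(N)=O)cc(OC)c21`, is not yet measured. It differs from compound 2 by pyridazin-3-yl in place of pyridin-2-yl on a carbonyl carbon. Within the data shown here, the only step that bears on this change is the one from compound 1 to compound 2, and its size is not readable; so no step beyond the scatter can be expected in either direction, and the most likely outcome is that this assay again returns a limit rather than a number. Compound 3 is estimated at 150000 nM, with a range from 50000 nM to 500000 nM. This expectation amounts to a step that the limit leaves unreadable from compound 2 to compound 3.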

Compound 3, half-maximal effective concentration: > 100000 nM
Compound 3 ended at the assay's limit (the forecaster's own chance of this, stated with the estimate: 85%); the middle value does not contradict the limit.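

In this assay compound 3 gives > 100000 nM, a limit of the assay and not a number. No step among compound 1, compound 2 and compound 3 can be read, because all three stand at the same limit: the limit of > 100000 nM in this assay, at which 3 of the 3 values shown sit.

Still open, as far as these compounds go, is whether the quinolin-2-yl, pyridin-2-yl and pyridazin-3-yl groups on the carbonyl carbon differ at all in this assay, and which structure would give a number rather than a limit.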